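Amide variation on the shared core: the cinnamoyl analogue

A few compounds are considered here, and "the series" means these few. Any claim that something is new, unique, unknown or untested is made for them only; others in the source may bear on it.

Measured compounds:
compound 1 `O=C(Nc1nnc(-c2ccc3c(c2)OCCO3)s1)c1ccccc1`; compound 2 `Cc1ccccc1C(=O)Nc1nnc(-c2ccc3c(c2)OCCO3)s1`; compound 3 `O=C(CCc1ccccc1)Nc1nnc(-c2ccc3c(c2)OCCO3)s1`.

In a functional assay on HepG2 cells (Homo sapiens) for antiproliferative activity, read by MTT assay, with a stated time of 48 h (a higher number here means that more compound is needed for the effect, a lower number that less compound is needed), compound 1 gives 34.8 ug/mL. Compound 2 reaches only a limit of the assay, > 100 ug/mL. Compound 3 gives 15.3 ug/mL, the lowest of the two numbers shown; its nearest neighbour is compound 1, with a 2.3-fold lower number from compound 1 to compound 3 (0.36 log units; beyond the scatter). Compound 4 `O=C(/C=C/c1ccccc1)Nc1nnc(-c2ccc3c(c2)OCCO3)s1` differs from compound 3 in 2-phenylethenyl in place of phenethyl on a carbonyl carbon. For the measured compounds named here, the measured steps that bear on the carbonyl substituent are a 2.3-fold lower number from compound 1 to compound 3 (0.36 log units; beyond the scatter) and an at least 6.5-fold lower number from compound 2 to compound 3 (0.81 log units; beyond the scatter), both favouring the two-carbon chain over a directly attached ring; no step exchanges a saturated chain for an unsaturated one. Compound 4 is therefore expected to stay close to compound 3, with a 1.0-fold higher number from compound 3 to compound 4 (0.02 log units; within the scatter), not beyond the scatter. The estimate for compound 4 is 16 ug/mL, with a range of 7 ug/mL to 38 ug/mL.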

Compound 4, half-maximal effective concentration: 10.3 ug/mL
Estimate against measurement, compound 4: 1.6-fold (0.19 log units) above, and the stated range covers the measured number.
By their numbers in this assay, from the lowest: compounds 4 and 3 (each within the scatter of the next); then compound 1. At a limit, above all of these: compound 2.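

With a 1.5-fold lower number from compound 3 to compound 4 (0.17 log units; within the scatter), the double bond added to the chain on the carbonyl carbon does not separate 2-phenylethenyl from phenethyl. The 2-phenylethenyl group also stands apart from the directly attached rings, with a 3.4-fold lower number from compound 1 to compound 4 (0.53 log units; beyond the scatter) and an at least 9.7-fold lower number from compound 2 to compound 4 (0.98 log units; beyond the scatter). The second of these steps rests on a limit for compound 2: the limit of > 100 ug/mL in this assay, at which 1 of the 4 values shown sits.

Open, on these data alone, is whether a longer chain on the carbonyl carbon would move the number. Also open, as far as these compounds go, is what an amine or a carboxylic acid in place of the phenyl ring would do.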